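Benzyl ether aryl swap in the thione series

This account rests on a few compounds, and the source may have more. Where it says the series, first, only, none or still open, it means among the compounds named here.

Among the measured compounds shown here, compound 3 `COc1ccc(COc2ccc(-c3nn(CCC#N)c(=S)o3)cc2)cc1` gives 910 nM in an assay for inhibition of Amine oxidase [flavin-containing] B (Rattus norvegicus) (a higher number here means a weaker inhibitor, a lower number a stronger inhibitor), the highest of the three numbers so far. Compound 2 `COc1cccc(COc2ccc(-c3nn(CCC#N)c(=S)o3)cc2)c1` gives 100 nM, and the step of a 9.1-fold higher number from compound 2 to compound 3 (0.96 log units; beyond the scatter) lies beyond the scatter. Compound 1 `Cc1ccc(COc2ccc(-c3nn(CCC#N)c(=O)o3)cc2)cc1`, carrying a carbonyl in the core and a 4-methylphenyl group, gives 15 nM; it differs from compound 3 in two places, so its value serves only as a reference point. Compound 4 `Cc1cccc(COc2ccc(-c3nn(CCC#N)c(=S)o3)cc2)c1` is not yet measured; the change is 3-methylphenyl in place of 4-methoxyphenyl on a saturated chain carbon bound to an oxygen on an aromatic ring. For the measured compounds named here, the only measured step that bears on this is a 9.1-fold higher number from compound 2 to compound 3 (0.96 log units; beyond the scatter), where the 3-substituted phenyl gave the lower number; read in reverse, a drop of comparable size is expected. Compound 4 is therefore estimated at 100 nM, range 30 nM to 400 nM. The expected step is a 9.1-fold lower number from compound 3 to compound 4 (0.96 log units; beyond the scatter).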

Compound 4, half-maximal inhibitory concentration: 66 nM
For compound 4 the middle estimate is 1.5-fold (0.18 log units) above the measured one; the range from low to high includes it.
By their numbers in this assay, from the lowest: compound 1; then compounds 4 and 2 (each within the scatter of the next); then compound 3.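

On the 3-substituted phenyl, methyl and methoxy on an aromatic carbon cannot be told apart in this assay (a 1.5-fold lower number from compound 2 to compound 4 (0.18 log units; within the scatter)). The swap from 4-methoxyphenyl to 3-methylphenyl gives a large change (a 14-fold lower number from compound 3 to compound 4 (1.14 log units; beyond the scatter)), so among the three thione compounds, compound 3 alone carries the high number. No supporting data explain this gap. Going by these compounds, whether an amine or a carboxylic acid in place of methyl on an aromatic carbon would hold the number of compound 4 remains open. Also open, on these data alone, is how 4-methylphenyl would compare with 3-methylphenyl in the thione series.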